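This account rests on a few compounds, and the source may have more. Where it says the series, first, only, none or still open, it means among the compounds named here.

Series notes. For the measured compounds named here, compound 1 `Oc1ccc(-c2cc(-c3cccs3)cc(-c3ccccc3O)n2)cc1` is the only member with a reported number: in an assay on isolated protein for inhibition of DNA topoisomerase 1 (Homo sapiens), with a stated time of 30 min, tested at 20 uM (a higher number here means a stronger effect of the compound at the concentration tested, a lower number a weaker effect), compound 1 gives 2%, a weak read-out at the test concentration. Compound 2 `Oc1ccc(-c2cc(-c3ccsc3)cc(-c3ccccc3O)n2)cc1` was reported in this assay only as "not determined" (no result reported), so compound 2 stands on no number, and nothing measured fixes where the series sits on moving from compound 2 to compound 3. Compound 3 `Oc1ccc(-c2cc(-c3ccsc3)cc(-c3ccc(O)cc3)n2)cc1` differs from compound 2 in one place: 4-hydroxyphenyl in place of 2-hydroxyphenyl on an aromatic carbon. Going by the values given here, with no measured step to rest on, the expected step in this assay for this change is none beyond the scatter, in no set direction, because compound 1 gives 2% in this assay and that small read-out leaves little room for a visible drop. Compound 3 is therefore expected to give about 5%, within 0% to 20%.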

Compound 3, a percentage reported as inhibition, at one concentration (the size of the read-out at that concentration, not a potency): 7.5%
Beside the measured number, compound 3's estimate is 2.5 percentage points below it, within the range that was stated.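

No step can be read from compound 2 to compound 3: in this assay compound 2 has no number, while compound 3 gives 7.5% and so stands alone. The compounds shown leave open how 4-hydroxyphenyl in place of 2-hydroxyphenyl affects this read-out. No evidence bears on this result.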